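Trimethoxybenzoyl cinnamamides: methoxy removal on the styryl ring

The source may hold more compounds than are shown below. What is called first, only, known or untested is meant among the compounds shown, and "the series" means these compounds.

Three measured compounds share a trimethoxybenzoyl anilide core carrying a cinnamamide. Compound 1 `COc1ccc(C(=O)c2cc(OC)c(OC)c(OC)c2)cc1NC(=O)/C=C/c1ccc(F)cc1` gives 3200 nM in a functional assay on PC-3 cells (Homo sapiens) for cytotoxicity, read by MTT assay, with a stated time of 72 h; a higher number here means a weaker inhibitor, a lower number a stronger inhibitor. Compound 2 `COc1cc(/C=C/C(=O)Nc2cc(C(=O)c3cc(OC)c(OC)c(OC)c3)ccc2OC)ccc1F` gives 14100 nM in this assay, and compound 3 `COc1ccc(/C=C/C(=O)Nc2cc(C(=O)c3cc(OC)c(OC)c(OC)c3)cc(OC)c2OC)cc1OC` gives 5400 nM in this assay.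

One single-point change is measured: from compound 2 to compound 1 the change is hydrogen in place of methoxy on an aromatic carbon, and it gives a 4.4-fold lower number from compound 2 to compound 1 (0.64 log units; beyond the scatter). The difference between the core of compound 3 and that of compound 2 is not broken down here. Compound 3 and compound 1 give numbers within the usual scatter of one another, while compound 3 sits beyond the scatter from compound 2.

Compound 4 `COc1ccc(/C=C/C(=O)Nc2cc(C(=O)c3cc(OC)c(OC)c(OC)c3)cc(OC)c2OC)cc1` is not yet measured in this assay. Its change from compound 3 is hydrogen in place of methoxy on an aromatic carbon. This is the same kind of change as that from compound 2 to compound 1, not the same: in compound 2 the departing methoxy sits ortho to a fluoro group, in compound 3 it sits ortho to a methoxy group, both meta to a large group. Within the data shown here, the only measured instance of this kind of change lowered the number, so the step from compound 3 to compound 4 is expected to lower the number as well, though a smaller step of a 2.0-fold lower number from compound 3 to compound 4 (0.30 log units; within the scatter) is estimated because the surroundings differ and only the one step of a 4.4-fold lower number from compound 2 to compound 1 (0.64 log units; beyond the scatter) supports it. Compound 4 is therefore expected to give about 2700 nM in this assay, estimated between 1100 nM and 7000 nM.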

Compound 4, half-maximal inhibitory concentration: 6300 nM
Beside the measured number, compound 4's estimate is 2.3-fold (0.37 log units) below it, within the range that was stated.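

Hydrogen in place of methoxy on the dimethoxy-bearing core gives a 1.2-fold higher number from compound 3 to compound 4 (0.07 log units; within the scatter) in this assay, a step that cannot be read as a gain or a loss on that core. The clear drop in the number seen on the fluoro-bearing core therefore does not carry over at the same size to this core: the same change on two cores in this assay, a 4.4-fold lower number (0.64 log units; beyond the scatter) from compound 2 to compound 1 and a 1.2-fold higher number (0.07 log units; within the scatter) from compound 3 to compound 4, 5.1-fold (0.71 log units) apart, beyond the scatter of two such steps. This shows that, for these two pairs, the result of the change depends on the core; it does not show which of the several differences between the core of compound 2 and that of compound 3 is responsible, and two pairs give no rule for the wider series.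

It remains open whether the fluoro group on the styryl ring or the additional methoxy on the anilide ring decides the size of the step, as no pair shown separates the two. Also open, as far as these compounds go, is how other groups at the place vacated by methoxy, such as a hydroxy group, a chloro group or an amine, would compare with hydrogen and methoxy on either core.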